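The source may hold more compounds than are shown below. What is called first, only, known or untested is meant among the compounds shown, and "the series" means these compounds.

In an ADME assay on WI-38 cells (Homo sapiens) for cytotoxicity, read by MTT assay, with a stated time of 72 h (on this read-out lower numbers stand for stronger inhibition and higher numbers for weaker inhibition), compound 1 `O=C(CCc1cccc2c1B(O)OC2)Nc1cccc(Br)c1` gives 20000 nM and compound 3 `C#Cc1ccccc1NC(=O)CCc1cccc2c1B(O)OC2` gives 18000 nM, two values that sit close together. Compound 2 `C#Cc1cccc(NC(=O)CCc2cccc3c2B(O)OC3)c1` gives > 100000 nM, which is a limit of the assay and not a number. For the measured compounds named here, compound 2 therefore has no exact place on the scale, and it is the one compound at the limit of > 100000 nM in this assay, at which 1 of the 3 values shown sits.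

The next compound to consider is compound 4 `O=C(CCc1cccc2c1B(O)OC2)Nc1cccc(-c2ccc(F)cc2)c1`. The change is 4-fluorophenyl in place of ethynyl on an aromatic carbon, with 4-fluorophenyl in place of ethynyl on an aromatic carbon, meta to a large group. Going by the values given here, one measured step bears on it: ethynyl in place of bromo on an aromatic carbon shows an at least 5.0-fold higher number from compound 1 to compound 2 (0.69 log units; beyond the scatter), which lies beyond the scatter. Here the ethynyl compound has the higher number. Compound 3 also carries ethynyl and still gives 18000 nM, so the group does not always go with the higher number.

Replacing ethynyl in compound 2 should therefore bring the number down, towards the level of compound 1 at 20000 nM, though 4-fluorophenyl has not been tested here. The expected change is an at least 5.0-fold lower number from compound 2 to compound 4 (0.69 log units; beyond the scatter), a move towards stronger inhibition. For compound 4 the estimated value is 20000 nM, with an expected range from 6000 nM to 80000 nM.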

Compound 4, half-maximal inhibitory concentration: 4100 nM
For compound 4 the middle estimate is 4.9-fold (0.69 log units) above the measured one, and the stated range ends above it.
By their numbers in this assay, from the lowest: compound 4; then compounds 3 and 1 (each within the scatter of the next). At a limit, above all of these: compound 2.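

At this place on the aromatic ring, meta to a large group, three groups can now be compared in this assay, and the largest of them, 4-fluorophenyl, carries the lowest number, so a larger group here does not by itself go with a higher number. Putting 4-fluorophenyl in place of ethynyl gives an at least 24-fold lower number from compound 2 to compound 4 (1.38 log units; beyond the scatter), and putting it in place of bromo gives a 4.9-fold lower number from compound 1 to compound 4 (0.69 log units; beyond the scatter), so the new group does more than return the number to the level of the bromo compound: it goes past that level, towards stronger inhibition of these cells. The first of these steps starts from compound 2, whose value is a limit of the assay and not a number: the limit of > 100000 nM in this assay, at which 1 of the 4 values shown sits.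

The compounds shown leave open whether the lower number goes with the added ring or with its fluorine, a question that plain phenyl or 4-chlorophenyl at the same place would help to settle. They also leave open how an amine or a carboxylic acid would read at this place, and whether 4-fluorophenyl would give a similar number at the place that ethynyl holds in compound 3.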